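Cytotoxicity notes: from compound 3 to compound 4

The source may hold more compounds than are shown below. What is called first, only, known or untested is meant among the compounds shown, and "the series" means these compounds.

Measured so far in an ADME assay on A549 cells (Homo sapiens) for cytotoxicity, read by resazurin assay, with a stated time of 48 h; a lower number here means that less compound is tolerated, a higher number that more compound is tolerated:

compound 1 `CC(C)Nc1ccc(NC(=O)c2cc(Cl)ccc2O)c(Cl)c1`: 11000 nM
compound 2 `CCCN(CCC)c1ccc(NC(=O)c2cc(Cl)ccc2O)c(Cl)c1`: 10700 nM
compound 3 `O=C(Nc1ccc(NCc2cc(F)cc(Cl)c2)cc1Cl)c1cc(Cl)ccc1O`: 11100 nM

Compound 3 sits within the scatter of both other compounds in this assay : the step of a 1.0-fold higher number from compound 1 to compound 3 (0.00 log units; within the scatter) and the step of a 1.0-fold lower number from compound 1 to compound 2 (0.01 log units; within the scatter) are both flat. Across the three, the group on the nitrogen on the aromatic ring of the shared core has been varied from isopropyl to dipropyl and to 3-chloro-5-fluorobenzyl without any change beyond the scatter.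

Compound 4 `O=C(Nc1ccc(NCCCO)cc1Cl)c1cc(Cl)ccc1O` is not yet measured. Its change from compound 3 is 2-hydroxyethyl in place of 3-chloro-5-fluorophenyl on a saturated chain carbon bound to a nitrogen on an aromatic ring. No measured step exchanges an aromatic group for a short hydroxyalkyl chain at this place, so the two steps above bear on it only in that this position has so far shown no movement: the step from compound 1 to compound 3 covered a larger change in the same place and stayed flat.

The expectation for compound 4 in this assay is therefore no step beyond the scatter, a 1.0-fold lower number from compound 3 to compound 4 (0.00 log units; within the scatter). The estimate for compound 4 is 11000 nM, within 5500 nM to 22000 nM.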

Compound 4, half-maximal cytotoxic concentration: 106000 nM
Estimate against measurement, compound 4: 9.6-fold (0.98 log units) below; the whole stated range lies below it.
By their numbers in this assay, from the lowest: compounds 2, 1 and 3 (each within the scatter of the next); then compound 4.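

In this assay, the group on this nitrogen is not silent after all: exchanging 3-chloro-5-fluorobenzyl for 3-hydroxypropyl gives a 9.5-fold higher number from compound 3 to compound 4 (0.98 log units; beyond the scatter), and the dipropylamino and isopropylamino comparisons give a 9.9-fold higher number from compound 2 to compound 4 (1.00 log units; beyond the scatter) and a 9.6-fold higher number from compound 1 to compound 4 (0.98 log units; beyond the scatter), so the three earlier groups, flat among themselves, all stand apart from the 3-hydroxypropyl group. Loss of the aromatic ring is not needed for the step, since neither the isopropyl group of compound 1 nor the 3-hydroxypropyl group of compound 4 carries a ring, and size alone does not order these compounds, since the small isopropyl and the larger 3-chloro-5-fluorobenzyl read alike. No accompanying measurement bears on the origin of this step.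

From the compounds shown here alone, whether the hydroxyl itself carries the step remains open; a plain propyl group or a 3-methoxypropyl chain on the same nitrogen would test that directly. Going by these compounds, how far the effect extends is also open, for instance with a longer hydroxyalkyl chain, or with an amine or a carboxylic acid at the chain end.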